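This account rests on a few compounds, and the source may have more. Where it says the series, first, only, none or still open, it means among the compounds named here.

Measured compounds:
compound 1, `O=C(O)CC[C@H](NC(=O)c1cc2ccccc2[nH]1)C(=O)N(C1CCCCC1)C1CCCCC1` — 3400 nM
compound 2, `CCCCCN(CCCCC)C(=O)C(CCC(=O)OCc1ccccc1)NC(=O)Nc1ccc(Cl)cc1` — 16000 nM
compound 3, `CCCCCN(CCCCC)C(=O)[C@@H](CCC(=O)O)NC(=O)Nc1cccc(OC)c1` — 9700 nM

In an assay for inhibition of Cholecystokinin receptor type A (Cavia porcellus) (on this read-out higher numbers stand for weaker inhibition and lower numbers for stronger inhibition), compound 3 gives 9700 nM, the second highest of the three numbers. Its nearest neighbour is compound 2, whose value of 16000 nM lies within the usual scatter of compound 3, so the two cannot be told apart. Compound 1, with 3400 nM, stands further away, beyond the scatter, and shows the lower number of the set.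

Compound 4, `CCCCCN(CCCCC)C(=O)[C@H](CCC(=O)O)NC(=O)Nc1cccc(OC)c1`, has not yet been measured in this assay. It differs from compound 3 as follows: the two compounds have the same atoms and bonds and differ only in configuration as drawn: 1 of 1 stereo elements differ; a stereocentre at a saturated chain carbon is drawn R in compound 3 and S in compound 4. Among the measured compounds shown here, since no pair of measured compounds differs in this way, there is no step on record to lean on. An enantiomeric switch in such a series is often not silent, but its direction cannot be read from the numbers given. The step from compound 3 to compound 4 is estimated as a 2.1-fold higher number from compound 3 to compound 4 (0.31 log units; beyond the scatter), leaning toward a weaker result. Compound 4 is thus expected to give about 20000 nM, with a likely range from 6000 nM to 60000 nM.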

Compound 4, half-maximal inhibitory concentration: 710 nM
The estimate for compound 4 lay 28-fold (1.45 log units) above the measured number; the whole stated range lies above it.
By their numbers in this assay, from the lowest: compound 4; then compound 1; then compounds 3 and 2 (each within the scatter of the next).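

In this assay, among the compounds shown here, the stereocentre at the saturated chain carbon turns out to matter strongly, which the earlier compounds could not show, as no two of them differed in one place alone. Turning this centre from R to S gives a 14-fold lower number from compound 3 to compound 4 (1.14 log units; beyond the scatter), so the configuration here is far from silent, and the S form is the one with the lower number. The step can be assigned to this centre alone: the fact that compounds 3 and 4 differ only in the configuration as drawn

The compounds shown leave open whether the S configuration keeps its lower number when the pentyl chains or the methoxy group are changed. They also leave open how the S form would read with a sulfonic acid or a primary amine in place of the carboxylic acid.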